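The source may report more compounds than this note shows. Statements on the series, on what has been measured and on what is new or still open speak of the compounds shown alone.

Measured in a functional assay on A549 cells (Homo sapiens) for cytotoxicity; a higher number here means that more compound is needed for the effect, a lower number that less compound is needed:
- compound 1 `COC1=C(C)C(=O)/C(=C(O)/C=C/c2ccccc2OC)C(=O)C1(C)C`: 2.4 ug/mL
- compound 2 `COC1=C(C)C(=O)/C(=C(O)/C=C/c2ccc(F)cc2)C(=O)C1(C)C`: 3.3 ug/mL
- compound 3 `COC1=C(C)C(=O)/C(=C(O)/C=C/c2ccccc2C)C(=O)C1(C)C`: 4.6 ug/mL

Compound 3 lies within the usual scatter of both other compounds, as a 1.4-fold higher number from compound 2 to compound 3 (0.14 log units; within the scatter) and a 1.9-fold higher number from compound 1 to compound 3 (0.28 log units; within the scatter) show. Compound 4 `COC1=C(C)C(=O)/C(=C(O)/C=C/c2ccco2)C(=O)C1(C)C` keeps the shared core and differs from compound 3 in one group: furan-2-yl in place of 2-methylphenyl on a double-bonded chain carbon bound to a double-bonded chain carbon. Put simply, this is furan-2-yl in place of 2-methylphenyl.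

Going by the values given here, no measured compound carries furan-2-yl, so the data offer no direct precedent for this change. The closest evidence comes from the other changes to this group. Besides the two steps above, there is a 1.4-fold higher number from compound 1 to compound 2 (0.14 log units; within the scatter), and all three stayed within the scatter. A step beyond the scatter in this assay is therefore not expected, and no direction is favoured. The estimated change is a 1.4-fold lower number from compound 3 to compound 4 (0.13 log units; within the scatter). For compound 4 the expected value is 3.4 ug/mL, with an estimated range from 1.7 ug/mL to 7 ug/mL.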

Compound 4, concentration for half-maximal effect: 10 ug/mL
Compound 4: the middle estimate sits 2.9-fold (0.47 log units) below what was measured; measured number outside the range, above it.
By their numbers in this assay, from the lowest: compounds 1, 2 and 3 (each within the scatter of the next); then compound 4.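

Up to this point, swapping one substituted phenyl group for another at this place on the chain stayed within the scatter in this assay, whereas furan-2-yl is the first group to go beyond it: there is a 2.2-fold higher number from compound 3 to compound 4 (0.34 log units; beyond the scatter) and a 3.0-fold higher number from compound 2 to compound 4 (0.48 log units; beyond the scatter) and a 4.2-fold higher number from compound 1 to compound 4 (0.62 log units; beyond the scatter) in this assay. The position is therefore not indifferent to the group it carries, and all three steps run the same way, with more compound needed once the six-membered carbon ring gives way to the five-membered ring holding an oxygen. Nothing in the available data explains what lies behind this shift.

The compounds shown leave open whether a thiophen-2-yl group, with sulfur in the ring, would behave like furan-2-yl or like the phenyl groups. As far as these compounds go, a pyridine ring at this place is equally open.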